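The source may hold more compounds than are shown below. What is called first, only, known or untested is meant among the compounds shown, and "the series" means these compounds.

Measured so far:
compound 1, `Nc1ccccc1NC(=O)c1ccc(CSC(=S)N2CCCc3ccccc32)cc1` — 26.1%
compound 2, `N#Cc1ccc(N2CCN(C(=S)SCc3ccc(C(=O)Nc4ccccc4N)cc3)CC2)cc1` — 71.6%

Compound 2 holds the higher of the two numbers in a functional assay on HeLa cells (Homo sapiens) for antiproliferative activity, read by CCK-8 assay, with a stated time of 72 h, tested at 2 uM; a lower number here means a weaker effect, a higher number a stronger effect of the compound at the concentration tested; compound 1 lies far enough below it that the gap is outside the usual scatter. Compound 3, `Nc1ccccc1NC(=O)c1ccc(CSC(=S)N2CCN(C3CCCCC3)CC2)cc1`, departs from compound 2 by one change: cyclohexyl in place of 4-cyanophenyl on an amine nitrogen in a ring. Among the measured compounds shown here, no measured pair differing in only one place exists to guide this, so the size of the step is uncertain. A moderate fall in this assay is expected, about a number 21.6 percentage points lower from compound 2 to compound 3 (beyond the scatter). For compound 3 the estimate in this assay is 50%, with a plausible range from 25% to 75%.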

Compound 3, a percentage reported as inhibition, at one concentration (the size of the read-out at that concentration, not a potency): 30.6%
Compound 3: middle estimate off by 19.4 percentage points, on the high side; low and high end bracket the measured number.
By their numbers in this assay, from the lowest: compounds 1 and 3 (each within the scatter of the next); then compound 2.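

In this assay, among the compounds shown here, cyclohexyl in place of 4-cyanophenyl on the amine nitrogen in the ring gives the first single-place step, a number 41 percentage points lower from compound 2 to compound 3 (beyond the scatter), so the result depends on the group at this position. No data shown explain the size of this step.

Compound 2 and compound 3 differ in both the ring and the nitrile, so these two contributions remain unseparated. A plain phenyl or a 4-methoxyphenyl at this position would help to separate them.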